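The compounds below may be only part of what the source reports. "The series", "measured", "known", "first", "only" and "open" are said of these compounds alone.

In a functional assay on A549 cells (Homo sapiens) for inhibition, read by CCK-8 assay, with a stated time of 48 h (a higher number here means a weaker inhibitor, a lower number a stronger inhibitor), the three measured compounds stand as follows:

compound 1 `COc1cc(-c2ccnc3cc(-c4c[nH]c5ccccc45)nn23)cc(OC)c1OC`: 29 nM
compound 2 `COc1cc(-c2ccnc3cc(-c4ccc(C(F)(F)F)cc4)nn23)cc(OC)c1OC`: 2070 nM
compound 3 `COc1cc(-c2ccnc3cc(-c4ccc5ccn(C)c5c4)nn23)cc(OC)c1OC`: 829 nM

Compound 1 gives the lowest number of the three; compound 3 is nearest to it and compound 2 furthest, and both steps away from compound 1 lie beyond the scatter. Compound 4 `COc1cc(-c2ccnc3cc(-c4ccc5cnn(C)c5c4)nn23)cc(OC)c1OC` has not yet been measured. It differs from compound 1 in one place: 1-methyl-1H-indazol-6-yl in place of 1H-indol-3-yl on an aromatic carbon. Going by the values given here, two measured steps bear on this change, as each also removes the 1H-indol-3-yl group: a 71-fold higher number from compound 1 to compound 2 (1.85 log units; beyond the scatter) and a 29-fold higher number from compound 1 to compound 3 (1.46 log units; beyond the scatter). The second is the closer parallel, as the entering group of compound 4, like that of compound 3, is a 1-methyl fused bicycle with 0 hydrogen-bond donors. The step of a 2.5-fold lower number from compound 2 to compound 3 (0.40 log units; beyond the scatter) shows that the two replacements already measured differ from each other only modestly. A large rise in this assay is therefore expected, of about a 28-fold higher number from compound 1 to compound 4 (1.44 log units; beyond the scatter), because the step of a 29-fold higher number from compound 1 to compound 3 (1.46 log units; beyond the scatter) was of that size. Compound 4 is estimated at 800 nM, within a range from 250 nM to 2500 nM.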

Compound 4, half-maximal inhibitory concentration: 233 nM
For compound 4 the middle estimate is 3.4-fold (0.54 log units) above the measured one; measured number below the stated range.
By their numbers in this assay, from the lowest: compound 1; then compound 4; then compound 3; then compound 2.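

In this assay, the position on the five-membered aromatic ring of the core separates two closely related entering groups, with 1-methyl-1H-indazol-6-yl giving a 3.6-fold lower number from compound 3 to compound 4 (0.55 log units; beyond the scatter). Going by these compounds alone, removing the 1H-indol-3-yl group therefore need not cost as much as the earlier compounds suggested, although an 8.0-fold higher number from compound 1 to compound 4 (0.90 log units; beyond the scatter) still leaves compound 4 beyond the scatter from compound 1, and an 8.9-fold lower number from compound 2 to compound 4 (0.95 log units; beyond the scatter) places it well clear of the 4-(trifluoromethyl)phenyl replacement. Nothing measured here accounts for these differences.

The compounds shown do not separate the change from 3-yl to 6-yl attachment from the loss of the hydrogen-bond donor, as compound 3 and compound 4 carry both changes at once relative to compound 1. Going by these compounds, how a 1H-indol-6-yl or 1H-indazol-3-yl group would stand at this position remains open.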